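The compounds below may be only part of what the source reports. "The series", "measured", "known", "first", "only" and "open" are said of these compounds alone.

Of the compounds shown here, three that share one core have been measured in a functional assay on MKN-45 cells (Homo sapiens) for cytotoxicity, read by MTT assay, with a stated time of 72 h; on this read-out higher numbers stand for weaker inhibition and lower numbers for stronger inhibition. Compound 1 `CN(C)CCn1cnnc1-c1cc(Oc2ccc(NC(=O)N/N=C/c3ccc(Cl)cc3Cl)cc2F)ccn1` gives 750 nM in this assay. Compound 2 `CN(C)CCn1cnnc1-c1cc(Oc2ccc(NC(=O)N/N=C/c3ccccc3O[N+](=O)[O-])cc2F)ccn1` gives 1020 nM, and compound 3 `COc1cc(/C=N/NC(=O)Nc2ccc(Oc3ccnc(-c4nncn4CCN(C)C)c3)c(F)c2)cc(OC)c1OC` gives 2900 nM. Compound 3 therefore stands highest of the three numbers: the nearest to it is compound 2 and the furthest is compound 1, and both gaps lie beyond the scatter. Compound 4 `CN(C)CCn1cnnc1-c1cc(Oc2ccc(NC(=O)N/N=C/c3ccc(F)cc3Cl)cc2F)ccn1` has not yet been measured. It differs from compound 3 in a single place: 2-chloro-4-fluorophenyl in place of 3,4,5-trimethoxyphenyl on a carbon with a double bond to nitrogen. Within the data shown here, two measured steps bear on this exchange: a 3.9-fold higher number from compound 1 to compound 3 (0.59 log units; beyond the scatter) and a 2.8-fold higher number from compound 2 to compound 3 (0.45 log units; beyond the scatter). Read in reverse, both show that swapping the 3,4,5-trimethoxyphenyl for another aryl group on the carbon with a double bond to nitrogen brought a modest fall in the number. Of the three measured groups, the 2-chloro-4-fluorophenyl entering in compound 4 most closely resembles the 2,4-dichlorophenyl of compound 1. A modest fall is therefore expected, a 3.6-fold lower number from compound 3 to compound 4 (0.56 log units; beyond the scatter). Compound 4 is expected to give about 800 nM, with a likely range from 400 nM to 1600 nM.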

Compound 4, half-maximal inhibitory concentration: 870 nM
Beside the measured number, compound 4's estimate is 1.1-fold (0.04 log units) below it, and the stated range covers the measured number.
By their numbers in this assay, from the lowest: compounds 1, 4 and 2 (each within the scatter of the next); then compound 3.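

Putting 2-chloro-4-fluorophenyl in place of 3,4,5-trimethoxyphenyl on the carbon with a double bond to nitrogen gives a 3.3-fold lower number from compound 3 to compound 4 (0.52 log units; beyond the scatter) in this assay, so compound 3 now stands apart from three different replacements rather than two. The new group cannot be told apart from the other two, since a 1.2-fold lower number from compound 2 to compound 4 (0.07 log units; within the scatter) and a 1.2-fold higher number from compound 1 to compound 4 (0.06 log units; within the scatter) both lie within the scatter, and fluoro in place of chloro on an aromatic carbon is therefore a change this assay does not resolve here. Nothing available explains why the number responds in this way.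

Every group shown at this position is a substituted phenyl ring, so the outcome with a ring carrying an amine or a carboxylic acid, or with a saturated cyclohexyl group, remains open. Also open, going by these compounds, is how a phenyl ring with a single chloro or a single methoxy would compare.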